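A few compounds are considered here, and "the series" means these few. Any claim that something is new, unique, unknown or untested is made for them only; others in the source may bear on it.

Of the compounds shown here, three have so far been tested in a physicochemical assay for solubility; a lower number here means a less soluble compound, a higher number a more soluble compound. Compound 1 (`O=C(O)c1ccc(C(=O)/C(=C\c2ccc(F)c([N+](=O)[O-])c2)SCc2ccc(Cl)cc2Cl)cc1`) gives < 1000 ug/mL and this is a limit of the assay, not a number. Compound 2 (`O=C(O)c1ccc(C(=O)/C(=C\c2ccc(O)c([N+](=O)[O-])c2)SCc2ccc(Br)cc2)cc1`) gives < 1000 ug/mL and this too is a limit. Compound 3 (`O=C(O)c1ccc(C(=O)/C(=C\c2ccc(F)c([N+](=O)[O-])c2)S(=O)(=O)Cc2ccc(Br)cc2)cc1`) gives < 1000 ug/mL and this is likewise only a limit, so its standing cannot be fixed any more closely. The whole set shows the limit of < 1000 ug/mL in this assay, at which 3 of the 3 values shown sit, and nothing separates the three compounds.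

Compound 4 (`O=C(O)c1ccc(C(=O)/C(=C\c2ccc(F)c([N+](=O)[O-])c2)Sc2ccc(Br)cc2)cc1`) is reached from compound 3 through (4-bromophenyl)sulfanyl in place of (4-bromobenzyl)sulfonyl on a double-bonded chain carbon bound to a carbonyl carbon and a double-bonded chain carbon and thus carries (4-bromophenyl)sulfanyl in place of (4-bromobenzyl)sulfonyl on a double-bonded chain carbon bound to a carbonyl carbon and a double-bonded chain carbon. One measured change touches this same place, namely a step that the two limits leave unreadable from compound 1 to compound 3 and it gives neither a size nor a direction, since both of its ends are limits. Among the measured compounds shown here, compound 2 offers no measured step at all. With so little to go on, no step beyond the scatter can be predicted in this assay and no direction can be favoured.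

The estimated step is a step that the limit leaves unreadable from compound 3 to compound 4 and it should be read as a loose expectation. Compound 4 is expected to give about 400 ug/mL with an estimated range from 50 ug/mL to 1000 ug/mL and it may well return only a limit.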

Compound 4, solubility: < 1000 ug/mL
Compound 4 gave a limit, no number; the forecaster's own chance of this, stated with the estimate: 85%; the middle value is on the limit's open side.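

In this assay compound 4 gives < 1000 ug/mL and this is a limit, not a number. No step can be read from compound 3 or compound 1 to compound 4, since all these values are limits: the limit of < 1000 ug/mL in this assay, at which 4 of the 4 values shown sit. The compounds shown leave open whether (4-bromophenyl)sulfanyl in place of (4-bromobenzyl)sulfonyl moves the read-out of this assay at all, and in which direction.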